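Dropping One Phenol From a Stilbene TRPV1 Probe

The compounds below may be only part of what the source reports. "The series", "measured", "known", "first", "only" and "open" are said of these compounds alone.

In an assay on HEK293 cells for agonist activity at transient receptor potential cation channel subfamily V member 1 (Homo sapiens), read by calcium flux (a lower number here means a smaller maximal response, a higher number a larger maximal response), compound 1 `Oc1ccc(/C=C/c2cccc(O)c2)cc1` reaches no more than the assay limit, returning < 10% rather than a number. Compound 2 `CC(=O)Oc1ccc(/C=C/c2ccccc2)cc1` likewise stops at the limit, < 10%, in this assay. Both recorded values thus sit at the floor of the readout, (the limit of < 10% in this assay, at which 2 of the 2 values shown sit). Compound 3 `Oc1cccc(/C=C/c2ccccc2)c1` differs from compound 1 by hydrogen in place of hydroxy on an aromatic carbon. Among the measured compounds shown here, no measured step covers such a change, so no shift beyond the usual scatter is expected in this assay, neither upward nor downward. Compound 3 is therefore estimated to give about 6% in this assay, within 0% to 15%. The step implied by this estimate, a step that the limit leaves unreadable from compound 1 to compound 3, is expected to be negligible.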

Compound 3, largest response reached (reported as efficacy), in percent of the reference or control that the assay uses: < 10%
Compound 3: a limit, no number; the forecaster's own chance of this, stated with the estimate: 70%; the middle value does not contradict the limit.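

No step can be read between compound 1 and compound 3, because both stop at a limit rather than a number: the limit of < 10% in this assay, at which 3 of the 3 values shown sit. The compounds shown leave open which change to the shared core, if any, would give a measurable response in this assay.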